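Swapping methylsulfanyl for trifluoromethyl on a fused core

This account rests on a few compounds, and the source may have more. Where it says the series, first, only, none or still open, it means among the compounds named here.

Compound 1 `CSc1nc2n(n1)C(c1ccc(O)cc1O)C([N+](=O)[O-])=NN2`: 201000 nM
Compound 2 `O=[N+]([O-])C1=CNc2nc(-c3ccco3)nn2C1c1ccc(O)cc1O`: 119000 nM
Compound 3 `O=[N+]([O-])C1=CNc2nc(C(F)(F)F)nn2C1c1c(O)cc(O)cc1O`: 838000 nM

In an ADME assay on MDCK cells (Canis lupus familiaris) for cytotoxicity (a lower number here means that less compound is tolerated, a higher number that more compound is tolerated), compound 1 gives 201000 nM, a number within the scatter of what compound 2 shows, while compound 3 gives a number beyond the scatter and clearly higher. Compound 4 `O=[N+]([O-])C1=NNc2nc(C(F)(F)F)nn2C1c1ccc(O)cc1O` keeps the core of compound 1 and changes one group: trifluoromethyl in place of methylsulfanyl on an aromatic carbon. For the measured compounds named here, no measured pair that differs in one place at this position is available, so the size of the step can only be guessed. Compound 3, which also carries trifluoromethyl, gives 838000 nM. Compound 4 is therefore expected to tolerate somewhat more than compound 1, a step of a 1.7-fold higher number from compound 1 to compound 4 (0.24 log units; within the scatter) that may not exceed the scatter. The estimate for compound 4 is 350000 nM, with a range from 120000 nM to 900000 nM.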

Compound 4, half-maximal cytotoxic concentration: 108000 nM
The estimate for compound 4 lay 3.2-fold (0.51 log units) above the measured number; measured number outside the range, below it.
By their numbers in this assay, from the lowest: compounds 4, 2 and 1 (each within the scatter of the next); then compound 3.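

In this assay, for the compounds shown here, the swap gives the first direct reading at this position, a 1.9-fold lower number from compound 1 to compound 4 (0.27 log units; within the scatter), with methylsulfanyl replaced by trifluoromethyl on an aromatic carbon. On the core of compound 1, this change therefore leaves the number within the usual variation between repeats, so any real effect of the swap cannot be told apart from that variation. No measured information is available to explain the result. The compounds shown leave open whether an amine or a longer chain at this position would move the number beyond the scatter.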